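Swapping the aromatic ring on the piperazine nitrogen

A few compounds are considered here, and "the series" means these few. Any claim that something is new, unique, unknown or untested is made for them only; others in the source may bear on it.

Compound 2 `O=C([C@@H]1C[C@H](N2CCN(c3ccc(Cl)cn3)CC2)CN1)N1CCSC1` shows the lowest number of the two measured in an assay on a cell-free system (plasma) for inhibition of Dipeptidyl peptidase 4 (Rattus norvegicus), read by fluorescence (on this read-out lower numbers stand for stronger inhibition and higher numbers for weaker inhibition), giving 3.1 nM; its nearest neighbour, compound 1 `CN1CCN([C@@H]2CN[C@H](C(=O)N3CCSC3)C2)CC1`, gives 81.1 nM. Among the measured compounds shown here, the one measured step, a 26-fold lower number from compound 1 to compound 2 (1.42 log units; beyond the scatter), is the only evidence bearing on this position. Compound 3 `O=C([C@@H]1C[C@H](N2CCN(c3ccncc3)CC2)CN1)N1CCSC1` carries pyridin-4-yl in place of 5-chloropyridin-2-yl on an amine nitrogen in a ring. Since that step reflects an aromatic ring replacing methyl, and compound 3 keeps an aromatic ring there, a small to moderate rise in number is expected, within the range shown by compound 1. Compound 3 is therefore estimated at 15 nM (range 4 nM to 60 nM), a step of a 4.8-fold higher number from compound 2 to compound 3 (0.68 log units; beyond the scatter).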

Compound 3, half-maximal inhibitory concentration: 3.9 nM
For compound 3 the middle estimate is 3.8-fold (0.59 log units) above the measured one; measured number below the stated range.
By their numbers in this assay, from the lowest: compounds 2 and 3 (each within the scatter of the next); then compound 1.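

In this assay, pyridin-4-yl in place of 5-chloropyridin-2-yl gives a 1.3-fold higher number from compound 2 to compound 3 (0.10 log units; within the scatter), so the chlorine is not required for a low number at this position. The gain over methyl also holds for a second aromatic ring, with a 21-fold lower number from compound 1 to compound 3 (1.32 log units; beyond the scatter), so it does not belong to 5-chloropyridin-2-yl alone. Nothing measured here explains why these two rings give matching numbers.

Going by these compounds, whether a plain phenyl ring, with no ring nitrogen, would do the same remains open. So does whether a non-aromatic cyclohexyl ring or a longer chain such as benzyl would keep the low number.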